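Shortening an ethoxy group: from compound 1 to compound 4

This account rests on a few compounds, and the source may have more. Where it says the series, first, only, none or still open, it means among the compounds named here.

Of the compounds shown here, three sharing one core have been tested in a functional assay on HeLa cells (Homo sapiens) for inhibition, with a stated time of 72 h; a higher number here means that more compound is needed for the effect, a lower number that less compound is needed. Compound 1 `CCOc1cc(CNCc2ccncc2)ccc1OCc1ccc(Cl)cc1` gives 2500 nM, the second highest of the three numbers. Compound 2 `COc1cc(OCc2cnc(Cl)c(Cl)c2)ccc1CNCc1ccncc1` gives 400 nM, a clearly lower number, while compound 3 `COc1cc(CNCC2CCCO2)ccc1OCc1ccc(Cl)nc1` gives 66000 nM, a far higher one. Compound 4 `COc1cc(CNCc2ccncc2)ccc1OCc1ccc(Cl)cc1` is not yet measured. It differs from compound 1 in one place only: hydrogen in place of methyl on a saturated chain carbon bound to an oxygen on an aromatic ring. For the measured compounds named here, no measured pair shows this change alone, and compound 2 and compound 3 differ from compound 1 elsewhere as well, so their numbers give no clean guide. A step no larger than the usual scatter, perhaps slightly toward a lower number, is expected in this assay. Compound 4 is estimated at 1800 nM, with a range from 500 nM to 6500 nM, which means an expected step of a 1.4-fold lower number from compound 1 to compound 4 (0.14 log units; within the scatter).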

Compound 4, half-maximal effective concentration: 890 nM
Compound 4: the middle estimate sits 2.0-fold (0.31 log units) above what was measured, and the stated range covers the measured number.
By their numbers in this assay, from the lowest: compound 2; then compound 4; then compound 1; then compound 3.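

In this assay, shortening ethoxy to methoxy gives a 2.8-fold lower number from compound 1 to compound 4 (0.45 log units; beyond the scatter). For the compounds shown here, this is the first clean reading of this position, and it shows that losing a single methyl here is enough to shift the number modestly past the usual scatter, toward less compound needed. Nothing measured explains the shift. Still open, going by these compounds, is how a longer chain, such as propoxy, or a branched isopropoxy group would read at this place. A free hydroxyl there also remains untested in the compounds shown.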